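Notes on replacing iodo with benzoyloxy in a short series

This account rests on a few compounds, and the source may have more. Where it says the series, first, only, none or still open, it means among the compounds named here.

Measured and pending in a functional assay (muscle tissue) with Cavia porcellus as the target; on this read-out higher numbers stand for an effect only at larger amounts of compound and lower numbers for an effect already at smaller amounts:
Compound 1 `COC(=O)C1=C(C)N=C(C)/C(=C(\O)OC)C1c1cccc(N)c1` - 2000 nM
Compound 2 `COC(=O)C1=C(C)N=C(C)/C(=C(\O)OC)C1c1cccc(I)c1` - 41.7 nM
Compound 3 `COC(=O)C1=C(C)N=C(C)/C(=C(\O)OC)C1c1cccc(OC(=O)c2ccccc2)c1` - not yet measured

Compound 2 holds the lower of the two numbers, and its gap to compound 1 lies beyond the scatter. The next change is benzoyloxy in place of iodo on an aromatic carbon, meta to a large group, counted in full as benzoyloxy in place of iodo on an aromatic carbon and leading to compound 3. Among the compounds with values here, one measured step bears on it: a 48-fold lower number from compound 1 to compound 2 (1.68 log units; beyond the scatter), a large step for iodo in place of amino at the same place. That step shows that the number in this assay can move strongly with the group there. Within the data shown here, it covers only amino and iodo, however, and no measured compound carries benzoyloxy. Among the measured compounds shown here, since compound 2 sits at 41.7 nM as the lower of only two values, a move to a higher number is expected rather than a further fall. The expected change is a 7.2-fold higher number from compound 2 to compound 3 (0.86 log units; beyond the scatter) and should remain smaller than the measured step. For compound 3 the estimate is 300 nM with an expected range from 60 nM to 1500 nM.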

Compound 3, half-maximal effective concentration: 6310 nM
Beside the measured number, compound 3's estimate is 21-fold (1.32 log units) below it; the whole stated range lies below it.
By their numbers in this assay, from the lowest: compound 2; then compound 1; then compound 3.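

In this assay the place on the aromatic carbon proves to run in both directions: a 150-fold higher number from compound 2 to compound 3 (2.18 log units; beyond the scatter) is a large step upward, set against the earlier 48-fold lower number from compound 1 to compound 2 (1.68 log units; beyond the scatter) in the opposite direction. Compound 1 also no longer marks the top of the series, since a 3.2-fold higher number from compound 1 to compound 3 (0.50 log units; beyond the scatter) is a modest step beyond the scatter and leaves benzoyloxy with the highest number of the three, so a group with more heavy atoms and a further six-membered aromatic ring does not carry the low number of iodo into this series. Nothing shown here speaks to what lies behind these steps.

Open, going by these compounds, is how an acetoxy group, a benzyloxy ether or a benzamide at this place would read, which would help separate the contribution of the ester carbonyl from that of the added aromatic ring. Within the data shown here, with only three groups at one place, it also stays open whether the order of compound 2, compound 1 and compound 3 would hold for a small halogen such as chloro or for a group on another carbon of the same ring.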